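Benzothiophene amide to phenylurea on a shared piperidine core

This account rests on a few compounds, and the source may have more. Where it says the series, first, only, none or still open, it means among the compounds named here.

Measured so far:
- Compound 1 `CC(C)[C@@H](NC(=O)c1cc2ccccc2s1)C(=O)N1CCC(c2ccc(Cl)cc2)CC1` gives 58 nM
- Compound 2 `CC[C@@H](NC(=O)c1ccccc1)C(=O)N1CCC(c2ccc(Cl)cc2)CC1` gives 121 nM
- Compound 3 `CC(C)C(NC(=O)OCc1ccccc1)C(=O)N1CCC(c2ccc(Cl)cc2)CC1` gives 1080 nM

These three compounds were tested in an assay on THP-1 cells for displacement of a labelled ligand from C-C chemokine receptor type 1 (Homo sapiens); a higher number here means a weaker inhibitor, a lower number a stronger inhibitor. Among them compound 1 has the lowest number, which marks it as the strongest inhibitor of the three: compound 2 sits beyond the scatter above it, and compound 3 lies far above both.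

The unmeasured compound 4 `CC(C)[C@@H](NC(=O)Nc1ccccc1)C(=O)N1CCC(c2ccc(Cl)cc2)CC1` keeps the core of compound 1 and alters only the group attached to the carbonyl carbon:

anilino in place of 1-benzothiophen-2-yl on a carbonyl carbon

Going by the values given here, no measured pair differs in this single place, so the size of the step can only be guessed from the spread of the three values. Compound 3, which also carries a different group at this carbonyl, gives 1080 nM, well above compound 1. A move toward a weaker inhibitor is therefore expected, though a smaller one than that.

For compound 4 a value of 300 nM is estimated, within 80 nM to 1200 nM. The expected step of a 5.2-fold higher number from compound 1 to compound 4 (0.71 log units; beyond the scatter) points toward a higher number, beyond the scatter.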

Compound 4, half-maximal inhibitory concentration: 616 nM
For compound 4 the middle estimate is 2.1-fold (0.31 log units) below the measured one, and the stated range covers the measured number.
By their numbers in this assay, from the lowest: compound 1; then compound 2; then compounds 4 and 3 (each within the scatter of the next).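

In this assay, putting anilino in place of 1-benzothiophen-2-yl on the carbonyl carbon gives an 11-fold higher number from compound 1 to compound 4 (1.03 log units; beyond the scatter). Going by these compounds alone, this is the first direct reading of this place, and it shows that inhibition responds strongly to the group attached there. The swap changes several things at once, replacing two aromatic rings with one and bringing in a hydrogen-bond donor, and no measurement here shows which of these changes accounts for the step.

This single step therefore cannot separate the loss of the 1-benzothiophen-2-yl ring system from the gain of the anilino nitrogen. It also leaves open how other groups at this place would behave, such as 2-naphthyl, which has two aromatic rings but no sulfur, or benzylamino, which keeps the nitrogen but adds a carbon before the ring.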